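This account rests on a few compounds, and the source may have more. Where it says the series, first, only, none or still open, it means among the compounds named here.

Working notes on the series. In a functional assay on the whole organism with Mus musculus as the target (a higher number here means that more compound is needed for the effect, a lower number that less compound is needed), compound 1 `CC[C@@H](C(=O)NC)N1CCCC1=O` gives 1800 umol/kg, compound 2 `CC[C@@H](C(=O)NO)N1CCCC1=O` gives 1000 umol/kg, and compound 3 `CC[C@@H](C(=N)S)N1CCCC1=O` gives 1000 umol/kg. Compound 3 is level with compound 2 at the digits shown, and all three values lie within the scatter of one another. Compound 4 `CC[C@@H](C(=N)NO)N1CCCC1=O` differs from compound 3 as follows: hydroxyamino in place of sulfanyl on a carbon with a double bond to nitrogen. This places hydroxyamino in place of sulfanyl on a carbon with a double bond to nitrogen. The measured steps that bear on this are a 1.8-fold lower number from compound 1 to compound 2 (0.26 log units; within the scatter), a 1.8-fold lower number from compound 1 to compound 3 (0.26 log units; within the scatter) and no change at the digits printed from compound 2 to compound 3 (within the scatter). All are within the scatter, though none makes this exact change. The expected step in this assay is no change at the digits printed from compound 3 to compound 4 (within the scatter), none beyond the scatter. For compound 4 the estimated value is 1000 umol/kg, with an expected range of 450 umol/kg to 2200 umol/kg.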

Compound 4, dose for half-maximal effect: 1000 umol/kg
Compound 4: the middle estimate sits on the measured number at the digits printed; measured number inside the range.
By their numbers in this assay, from the lowest: compounds 2, 3, 4 and 1 (each within the scatter of the next).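

On the carbon with a double bond to nitrogen, hydroxyamino in place of sulfanyl gives no change at the digits printed from compound 3 to compound 4 (within the scatter) in this assay, so this position accepts either group without a step beyond the scatter. The steps of no change at the digits printed from compound 2 to compound 4 (within the scatter) and a 1.8-fold lower number from compound 1 to compound 4 (0.26 log units; within the scatter) also stay within the scatter, so the new group adds no separation among the groups at this place. Nothing available bears on why these groups read alike.

Open, from the compounds shown here alone, is whether a carboxylic acid or an amine on the saturated chain carbon would give a step beyond the scatter.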